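The source may report more compounds than this note shows. Statements on the series, on what has been measured and on what is new or still open speak of the compounds shown alone.

Compound 2 `O[C@@H]1Cc2ccccc2[C@H]1NC1CCN(CCCc2c[nH]c3ccc(-n4cnnc4)cc23)CC1` holds the highest number of the two measured: in an assay on CHO cells for displacement of a labelled ligand from 5-hydroxytryptamine receptor 1B (Homo sapiens) (a lower number here means a stronger inhibitor, a higher number a weaker inhibitor), compound 2 gives 210 nM, while compound 1 `O=S(=O)(NCC1CCN(CCCc2c[nH]c3ccc(-n4cnnc4)cc23)CC1)c1ccccc1` gives 60 nM, and the step of a 3.5-fold higher number from compound 1 to compound 2 (0.54 log units; beyond the scatter) was modest. Compound 3 `c1cc(CNC2CCN(CCCc3c[nH]c4ccc(-n5cnnc5)cc34)CC2)co1` differs from compound 2 by (furan-3-yl)methyl in place of 2-hydroxy-2,3-dihydro-1H-inden-1-yl on an amine nitrogen. Among the compounds with values here, no measured step replaces a group on this amine nitrogen, so the only measured step offers loose guidance. For compound 3 the expected step of a 1.4-fold lower number from compound 2 to compound 3 (0.15 log units; within the scatter) is estimated to stay within the scatter. Compound 3 is estimated in this assay at 150 nM, between 50 nM and 500 nM.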

Compound 3, half-maximal inhibitory concentration: 78 nM
For compound 3 the middle estimate is 1.9-fold (0.28 log units) above the measured one, within the range that was stated.
By their numbers in this assay, from the lowest: compounds 1 and 3 (each within the scatter of the next); then compound 2.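

In this assay, (furan-3-yl)methyl in place of 2-hydroxy-2,3-dihydro-1H-inden-1-yl on the amine nitrogen gives a 2.7-fold lower number from compound 2 to compound 3 (0.43 log units; beyond the scatter), the first step shown at this nitrogen that lies beyond the scatter. The ((furan-3-yl)methyl)amino and ((phenylsulfonyl)amino)methyl groups on the saturated ring carbon are not separated, with a 1.3-fold higher number from compound 1 to compound 3 (0.11 log units; within the scatter), so compound 2 alone stands apart. No evidence is available that accounts for these results.

As far as these compounds go, whether a benzyl group or a 2-thienylmethyl group on this amine nitrogen would read like (furan-3-yl)methyl remains open. So does the part played by the hydroxyl and the two defined stereocentres of 2-hydroxy-2,3-dihydro-1H-inden-1-yl.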